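Chloro Added to the Sulfonyl Ring of Compound 2

This account rests on a few compounds, and the source may have more. Where it says the series, first, only, none or still open, it means among the compounds named here.

Compound 1 `CN(C(=O)c1ccccc1)c1ccc2[nH]c(-c3n[nH]c4ccccc34)cc2n1` gives 10600 nM in a functional assay on HCT-116 cells (Homo sapiens) for antiproliferative activity, read by MTT assay, with a stated time of 72 h; on this read-out lower numbers stand for stronger inhibition and higher numbers for weaker inhibition.
Compound 2 `CN(c1ccc2[nH]c(-c3n[nH]c4ccccc34)cc2n1)S(=O)(=O)c1ccccc1` gives 6740 nM in this assay.
Compound 3 `CN(c1ccc2[nH]c(-c3n[nH]c4ccccc34)cc2n1)S(=O)(=O)c1ccc(Cl)cc1` is not yet measured in this assay.

On the numbers shown, compound 2 gives the lowest of the two values, with compound 1 nearest; the step of a 1.6-fold lower number from compound 1 to compound 2 (0.20 log units; within the scatter) stays within the scatter, so the two cannot be placed in any order. Compound 3 differs from compound 2 by chloro in place of hydrogen on an aromatic carbon. No measured step touches this kind of change: the only step shown, from compound 1 to compound 2, swaps a benzoyl for a phenylsulfonyl and says nothing about a chloro on the ring. With nothing to lean on, compound 3 is expected to stay close to compound 2, the step of a 1.2-fold lower number from compound 2 to compound 3 (0.09 log units; within the scatter) being estimated to lie within the scatter. Compound 3 is therefore estimated at 5500 nM, in the range 2000 nM to 15000 nM.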

Compound 3, half-maximal inhibitory concentration: 5980 nM
Compound 3: middle estimate off by 1.1-fold (0.04 log units), on the low side; low and high end bracket the measured number.
By their numbers in this assay, from the lowest: compounds 3, 2 and 1 (each within the scatter of the next).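

In this assay, chloro in place of hydrogen on the phenyl ring of the sulfonyl group, para to a large group, gives a 1.1-fold lower number from compound 2 to compound 3 (0.05 log units; within the scatter) and so cannot be told apart from hydrogen at this position. Going further back, (4-chlorophenyl)sulfonyl in place of benzoyl gives a 1.8-fold lower number from compound 1 to compound 3 (0.25 log units; within the scatter), which means that compound 1 and compound 3 cannot be placed in any order either. No outside evidence bears on this result.

Still open, as far as these compounds go, is whether a different group at this same place, such as an amine or a carboxylic acid, would give a step beyond the scatter. Also open, from the compounds shown here alone, is whether chloro at another carbon of this ring would read any differently from the hydrogen of compound 2.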